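Swapping the pyrimidine on the sulfonamide nitrogen

The compounds below may be only part of what the source reports. "The series", "measured", "known", "first", "only" and "open" are said of these compounds alone.

Two compounds share a thiourea-linked core and differ only in the ring on the sulfonamide nitrogen. Compound 1 `O=S(=O)(Nc1ncccn1)c1ccc(N/C(S)=N\c2ccnc3cc(C(F)(F)F)ccc23)cc1` carries a plain pyrimidin-2-yl there; in a functional assay on LoVo cells (Homo sapiens) for antiproliferative activity, read by sulforhodamine B assay, with a stated time of 48 h (a higher number here means a weaker inhibitor, a lower number a stronger inhibitor), compound 1 gives 34700 nM. Compound 2 `Cc1cc(C)nc(NS(=O)(=O)c2ccc(N/C(S)=N\c3ccnc4cc(C(F)(F)F)ccc34)cc2)n1` carries a 4,6-dimethylpyrimidin-2-yl instead, and in this assay compound 2 gives 40200 nM. Compound 2 stands alongside compound 1, the two separated only by a 1.2-fold higher number from compound 1 to compound 2 (0.06 log units; within the scatter), so the pair cannot be told apart on these numbers. Compound 3 `COc1ncnc(NS(=O)(=O)c2ccc(N/C(S)=N\c3ccnc4cc(C(F)(F)F)ccc34)cc2)c1OC` is not yet measured; its change from compound 2 is 5,6-dimethoxypyrimidin-4-yl in place of 4,6-dimethylpyrimidin-2-yl on a sulfonamide nitrogen. For the measured compounds named here, only the step from compound 1 to compound 2 touches this ring, and it stayed within the scatter, so the expected step of a 1.1-fold lower number from compound 2 to compound 3 (0.02 log units; within the scatter) is none beyond the scatter. Compound 3 is therefore expected to give about 38000 nM, somewhere between 14000 nM and 100000 nM.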

Compound 3, half-maximal inhibitory concentration: 28400 nM
Compound 3: middle estimate off by 1.3-fold (0.13 log units), on the high side; the measured number falls inside the stated range.
By their numbers in this assay, from the lowest: compounds 3, 1 and 2 (each within the scatter of the next).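

Swapping 4,6-dimethylpyrimidin-2-yl for 5,6-dimethoxypyrimidin-4-yl on a sulfonamide nitrogen changes both the groups on the ring and the point at which the ring is attached, yet in this assay it produces only a 1.4-fold lower number from compound 2 to compound 3 (0.15 log units; within the scatter) and, set against the plain pyrimidin-2-yl, a 1.2-fold lower number from compound 1 to compound 3 (0.09 log units; within the scatter) as its other step. So the three pyrimidines cannot be told apart at this position, and that now holds for a ring carrying methoxy groups as well as for one carrying methyl groups. No accompanying measurement offers an explanation for this result.

From the compounds shown here alone, all three groups are pyrimidines, so it remains open whether a phenyl ring, a saturated ring such as piperidine or an open propyl chain would also stay within the scatter. Also open, going by these compounds, is whether a carboxylic acid or an amine on the pyrimidine would shift the number beyond it.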